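The source may hold more compounds than are shown below. What is called first, only, known or untested is meant among the compounds shown, and "the series" means these compounds.

Working notes on the hydroxypiperidine series sharing the core of compound 1.

Three compounds are recorded. Compound 1 `O=c1c2cnn(-c3ccc(F)cc3)c2ncn1CC1(O)CCN(Cc2ccncc2)CC1` carries a pyridinylmethyl group on the piperidine nitrogen; in an assay on Sf21 cells for inhibition of ubiquitin carboxyl-terminal hydrolase 7 (Homo sapiens), read by spectrophotometry, with stated times of 30 min and 2 h (a lower number here means a stronger inhibitor, a higher number a weaker inhibitor), compound 1 gives "not determined" (no result reported). Compound 2 `COC(=O)c1ccccc1CN1CCC(O)(Cn2cnc3c(cnn3-c3ccc(F)cc3)c2=O)CC1` carries a 2-(methoxycarbonyl)benzyl group; in this assay compound 2 gives "not determined" (no result reported). Within the data shown here, compound 3 `COC(=O)c1ccc(CN2CCC(O)(Cn3cnc4c(cnn4-c4ccc(F)cc4)c3=O)CC2)cc1` carries the 4-(methoxycarbonyl)benzyl group, and in this assay compound 3 gives 4500 nM; this is the only number in hand, so compound 3 cannot be placed relative to the others.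

Compound 4 `O=c1c2cnn(-c3ccc(F)cc3)c2ncn1CC1(O)CCN(Cc2ccc(Br)cc2Cl)CC1` is the next entry. The change from compound 3 is 4-bromo-2-chlorophenyl in place of 4-(methoxycarbonyl)phenyl on a saturated chain carbon bound to an amine nitrogen in a ring, cut one bond further out: 4-(methoxycarbonyl)benzyl to 4-bromo-2-chlorobenzyl. Among the measured compounds shown here, no step between measured compounds is available to calibrate this exchange. The expectation for compound 4 in this assay is a step of a 3.0-fold lower number from compound 3 to compound 4 (0.48 log units; beyond the scatter), towards a stronger inhibitor but of a size that may barely clear the scatter. The estimate for compound 4 in this assay is 1500 nM, with a range from 300 nM to 6000 nM.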

Compound 4, half-maximal inhibitory concentration: 1900 nM
Beside the measured number, compound 4's estimate is 1.3-fold (0.10 log units) below it, within the range that was stated.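

In this assay, among these compounds, the exchange of 4-(methoxycarbonyl)benzyl for 4-bromo-2-chlorobenzyl gives the first readable step, a 2.4-fold lower number from compound 3 to compound 4 (0.37 log units; beyond the scatter), a modest move towards a stronger inhibitor. On this pair, the methyl ester and its two hydrogen-bond acceptors are not needed for a measurable value, and an aryl group with no hydrogen-bond acceptors does somewhat better. The ester leaves and both halogens enter in one step. This pair cannot divide the gain among those changes. No supporting measurement explains it.

Steps to compound 1 and compound 2 cannot be read. Still open, going by these compounds, is how a carboxylic acid in place of the methyl ester, or 4-bromobenzyl with its single halogen, would compare with compound 3 and compound 4.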